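The source may hold more compounds than are shown below. What is called first, only, known or untested is meant among the compounds shown, and "the series" means these compounds.

Measured so far:
Compound 1 `Cc1cc(C)c(CN2CCc3c(Cl)cc([C@@H](CO)[C@@H]4CCCO4)c(Cl)c3C2=O)c(=O)[nH]1` gives 4.3 10^-6 cm/s in an ADME assay on MDCK cells (Canis lupus familiaris) for permeability, read by LC-MS, with a stated time of 90 min, tested at 2 uM; on this read-out lower numbers stand for lower permeability and higher numbers for higher permeability.
Compound 2 `Cc1cc(C)c(CN2CCc3c(Cl)cc([C@@H](C)CO)c(Cl)c3C2=O)c(=O)[nH]1` gives 15 10^-6 cm/s in this assay.
Compound 3 `COC(c1cc(Cl)c2c(c1Cl)C(=O)N(Cc1c(C)cc(C)[nH]c1=O)CC2)C1CCOC1` gives 17.1 10^-6 cm/s; 18.7 10^-6 cm/s; 15.4 10^-6 cm/s; 18.4 10^-6 cm/s (4 entries) in this assay, as several repeats (the several entries of compound 3 in this assay, 17.1 10^-6 cm/s; 18.7 10^-6 cm/s; 15.4 10^-6 cm/s; 18.4 10^-6 cm/s (4 entries)).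

Compound 2 stands highest of the two single numbers in this assay; the nearest is compound 1, and a 3.5-fold higher number from compound 1 to compound 2 (0.54 log units; beyond the scatter). Compound 4 `Cc1cc(C)c(CN2CCc3c(Cl)cc([C@H](CO)[C@H]4CCOC4)c(Cl)c3C2=O)c(=O)[nH]1` differs from compound 2 by oxolan-3-yl in place of methyl on a saturated chain carbon bound to an aromatic carbon and a saturated chain carbon. Among the compounds with values here, the only measured step that bears on this is the one from compound 1 to compound 2, where a ring of the same size was replaced by an open chain and the number rose. Going back to a five-membered ring is therefore expected to lower the number in this assay, by a modest step: a 2.5-fold lower number from compound 2 to compound 4 (0.40 log units; beyond the scatter) is expected. For compound 4 the estimate in this assay is 6 10^-6 cm/s, with a range from 3 10^-6 cm/s to 12 10^-6 cm/s.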

Compound 4, apparent permeability: 2.9 10^-6 cm/s
The estimate for compound 4 lay 2.1-fold (0.32 log units) above the measured number; measured number outside the range, below it.
By their numbers in this assay, from the lowest: compounds 4 and 1 (each within the scatter of the next); then compound 2.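

In this assay, oxolan-3-yl in place of methyl on this saturated chain carbon gives a 5.2-fold lower number from compound 2 to compound 4 (0.71 log units; beyond the scatter). This shows that the number is sensitive to the size of the group at this place. The two groups carrying a five-membered ring, with the same atom count, cannot be told apart here: a 1.5-fold lower number from compound 1 to compound 4 (0.17 log units; within the scatter).

No measurement shown explains why the number drops when this ring enters. Going by these compounds, whether a small amine, a carboxylic acid or a longer open chain at this carbon would read nearer compound 2 or compound 4 remains open.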